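A few compounds are considered here, and "the series" means these few. Any claim that something is new, unique, unknown or untested is made for them only; others in the source may bear on it.

For the measured compounds named here, compound 3 `O=c1[nH]c(=O)n(CCC(CO)CO)cc1C#CC1CC1` is one of three compounds measured in a functional assay on SW-620 cells (Homo sapiens) for antiproliferative activity, read by MTT assay, with a stated time of 72 h; a higher number here means a weaker inhibitor, a lower number a stronger inhibitor. In this assay compound 3 gives > 100000 nM, which is a limit and not a number. Compound 1 `O=c1[nH]c(=O)n(CCC(CO)CO)cc1-c1cccs1` gives > 100000 nM in this assay, again a limit. Compound 2 `CC(=O)OCC(CCn1cc(C#CCc2ccccc2)c(=O)n(C(=O)c2ccccc2)c1=O)COC(C)=O` is the only one of the three with a number, giving 36400 nM in this assay. Going by the values given here, the one step between measured neighbours reads a step that the two limits leave unreadable from compound 1 to compound 3, so the measured set says nothing about how a change at the triple-bonded carbon moves inhibition; what the set does show is the limit of > 100000 nM in this assay, at which 2 of the 3 values shown sit. Compound 4 `CC(C)(C)C#Cc1cn(CCC(CO)CO)c(=O)[nH]c1=O` differs from compound 3 by tert-butyl in place of cyclopropyl on a triple-bonded carbon. Among the compounds with values here, no measured step bears on a change of this kind, and compound 3 already sits at the limit, so compound 4 is expected to stay there as well. The expected step is a step that the limit leaves unreadable from compound 3 to compound 4, none beyond the scatter. Compound 4 is therefore estimated at 120000 nM in this assay, with a range from 30000 nM to 500000 nM, and most likely reported again only as a limit.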

Compound 4, half-maximal inhibitory concentration: > 100000 nM
Compound 4: only a limit was reported; the forecaster's own chance of this, stated with the estimate: 70%; the middle value does not contradict the limit.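

In this assay, for the compounds shown here, compound 1, compound 3 and compound 4 are all reported only as limits, so no step among them can be read. The compounds shown leave open whether any group on the triple-bonded carbon changes inhibition, as most values rest at one point: the limit of > 100000 nM in this assay, at which 3 of the 4 values shown sit.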